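Swapping the Aryl on the Triazole: Estimating Compound 4

This account rests on a few compounds, and the source may have more. Where it says the series, first, only, none or still open, it means among the compounds named here.

Compound 1 `N#CC1=C(N)Oc2c(c3nc4ccccc4nc3c3ccccc23)C12C(=O)N(Cc1cnnn1-c1ccc(Cl)cc1)c1ccccc12`: in a functional assay on A549 cells (Homo sapiens) for antiproliferative activity, read by MTT assay, with a stated time of 48 h (a lower number here means a stronger inhibitor, a higher number a weaker inhibitor), compound 1 gives > 50000 nM, which is a limit of the assay.
Compound 2 `Cc1ccccc1-n1nncc1CN1C(=O)C2(C(C#N)=C(N)Oc3c(N)cc4nc5ccccc5nc4c32)c2ccccc21`: in this assay compound 2 gives 31700 nM.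
Compound 3 `CC(=O)Nc1ccc(-n2nncc2CN2C(=O)C3(C(C#N)=C(N)Oc4c(N)cc5nc6ccccc6nc5c43)c3ccccc32)cc1`: in this assay compound 3 gives > 50000 nM, which is a limit of the assay.

Compound 3 therefore stands at the limit of > 50000 nM in this assay, at which 2 of the 3 values shown sit, with only a limit and no number of its own. Compound 4 `Cc1cc(C)cc(-n2nncc2CN2C(=O)C3(C(C#N)=C(N)Oc4c(N)cc5nc6ccccc6nc5c43)c3ccccc32)c1` differs from compound 3 by 3,5-dimethylphenyl in place of 4-acetamidophenyl on an aromatic nitrogen. Going by the values given here, the only measured step at this position is an at least 1.5-fold higher number from compound 2 to compound 3 (0.19 log units; that floor lies within the scatter), a change whose floor lies within the scatter, and both of its partners are weak inhibitors. Compound 4 is therefore expected to stay weak, with an at least 1.2-fold lower number from compound 3 to compound 4 (0.09 log units; that floor lies within the scatter) amounting to no step beyond the scatter. The estimate for compound 4 is 40000 nM, with a range from 15000 nM to 100000 nM.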

Compound 4, half-maximal inhibitory concentration: 31200 nM
The estimate for compound 4 lay 1.3-fold (0.11 log units) above the measured number; low and high end bracket the measured number.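

With a number now measured for compound 4, two aryl groups on this aromatic nitrogen can be compared directly: 3,5-dimethylphenyl in place of 2-methylphenyl gives a 1.0-fold lower number from compound 2 to compound 4 (0.01 log units; within the scatter), so this change shows no effect that can be told from scatter. Against 4-acetamidophenyl, the step is an at least 1.6-fold lower number from compound 3 to compound 4 (0.20 log units; that floor lies within the scatter), so it does not separate those two groups either. Compound 3 has only a limit of the assay: the limit of > 50000 nM in this assay, at which 2 of the 4 values shown sit.

Going by these compounds, how far compound 3 truly lies from compound 4 stays open. So does whether a carboxylic acid or an amine on this phenyl ring would give a clearly lower number.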